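Methyl Ester of Compound 1 Awaiting Measurement

This account rests on a few compounds, and the source may have more. Where it says the series, first, only, none or still open, it means among the compounds named here.

Compound 1 `Cc1[nH]n(-c2nc3ccccc3[nH]2)c(=O)c1CC(=O)O` gives 15000 nM in an assay on isolated protein for inhibition of alpha-ketoglutarate-dependent dioxygenase alkB homolog 3 (Homo sapiens), read by polymerase chain reaction, with a stated time of 1 h; on this read-out higher numbers stand for weaker inhibition and lower numbers for stronger inhibition.
Compound 2 `O=c1c(Cc2ccccc2)c(-c2ccccc2)[nH]n1-c1nc2ccccc2[nH]1` in this assay reaches only a limit, > 10000 nM.
Compound 3 `Cc1[nH]n(-c2nc3ccccc3n2C)c(=O)c1C` in this assay also reaches only a limit, > 10000 nM.

Within the data shown here, compound 1 therefore holds the only number in the set; the other two results are limits of the assay, as the limit of > 10000 nM in this assay, at which 2 of the 3 values shown sit, records. Compound 4 `COC(=O)Cc1c(C)[nH]n(-c2nc3ccccc3[nH]2)c1=O` differs from compound 1 by methyl in place of hydrogen on an oxygen next to a carbonyl group. Among the measured compounds shown here, no measured pair carries this change, so no size of step is known from the data; the weak number of compound 1 and the two limits leave only modest room for any change to be seen. Compound 4 is expected to give 20000 nM, with a range from 7000 nM to 60000 nM. For compound 4 this expectation amounts to a step of a 1.3-fold higher number from compound 1 to compound 4 (0.12 log units; within the scatter), not beyond the scatter.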

Compound 4, half-maximal inhibitory concentration: 4300 nM
For compound 4 the middle estimate is 4.7-fold (0.67 log units) above the measured one; measured number below the stated range.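

In this assay, among these compounds, the change from carboxy to methoxycarbonyl gives a 3.5-fold lower number from compound 1 to compound 4 (0.54 log units; beyond the scatter), the first step at this position with a readable size. The hydrogen on this oxygen is therefore not needed for the inhibition seen here, and methyl in its place moves the number toward stronger inhibition. Compound 4 also joins compound 1 as a second true number in a set whose other results are limits: the limit of > 10000 nM in this assay, at which 2 of the 4 values shown sit.

On these data alone, whether an ethyl ester or a primary amide at this place would go further remains open. This single pair also leaves open whether the same change would give a similar step on another core.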